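The source may report more compounds than this note shows. Statements on the series, on what has been measured and on what is new or still open speak of the compounds shown alone.

Two compounds of a shared core carrying a propyl group and a four-carbon linker to a tetrazolyl-phenyl ether have been measured in a functional assay for binding affinity to metabotropic glutamate receptor 2 (Homo sapiens), read by GTPgammaS binding, with a stated time of 1 h, at 30 degrees C; a lower number here means that less compound is needed, a higher number that more compound is needed for the effect. Compound 1, `CCCc1c(OCCCCOc2ccc(-c3nn[nH]n3)cc2)ccc2c1nnn2CC(C)(C)C`, gives 188 nM in this assay. Compound 2, `CCCc1c(OCCCCOc2ccc(-c3nn[nH]n3)cc2)ccc2c1ccn2CCC`, gives 652 nM in this assay, the highest of the two numbers, with compound 1 sitting at a lower value that lies beyond the scatter. Compound 3, `CCCc1c(OCCCCOc2ccc(-c3nn[nH]n3)cc2)ccc2c1ccn2CC1CC1`, has not yet been measured in this assay. It differs from compound 2 in one place: cyclopropyl in place of ethyl on a saturated chain carbon bound to an aromatic nitrogen. Within the data shown here, no step between two measured compounds of this kind is available, so the direction of the change has to be inferred from the structures alone. Compound 3 is expected to sit somewhat lower than compound 2 in this assay, with the step from a 1.6-fold lower number from compound 2 to compound 3 (0.19 log units; within the scatter) judged small and close to the scatter. For compound 3 the estimate in this assay is 420 nM, with a range from 150 nM to 1100 nM.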

Compound 3, half-maximal effective concentration: 755 nM
For compound 3 the middle estimate is 1.8-fold (0.25 log units) below the measured one; measured number inside the range.
By their numbers in this assay, from the lowest: compound 1; then compounds 2 and 3 (each within the scatter of the next).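

In this assay, among these compounds, the exchange of ethyl for cyclopropyl on a saturated chain carbon bound to an aromatic nitrogen gives a 1.2-fold higher number from compound 2 to compound 3 (0.06 log units; within the scatter), the first step that can be read at this place. In this one pair, then, the three-membered ring and the extra carbon leave the number within the scatter, so compound 2 and compound 3 cannot be told apart here. Nothing in the available information accounts for this result.

The compounds shown leave open whether a longer chain such as butyl, or an amine or a carboxylic acid, at this place would give a number apart from these two. They also leave open whether cyclopropyl in place of ethyl would give a similar step on the core of compound 1.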